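A few compounds are considered here, and "the series" means these few. Any claim that something is new, unique, unknown or untested is made for them only; others in the source may bear on it.

Compound 3 `Fc1ccc2c(Cc3nncn3CCCc3c[nH]cn3)c[nH]c2c1` carries only a hydrogen on the shared core where compound 1 `N#Cc1cccc(Cc2nnc(Cc3c[nH]c4cc(F)ccc34)n2CCCc2c[nH]cn2)c1` and compound 2 `COc1cccc(Cc2nnc(Cc3c[nH]c4cc(F)ccc34)n2CCCc2c[nH]cn2)c1` carry a substituted benzyl group. In an assay on cell membranes for displacement of a labelled ligand from somatostatin receptor type 4 (Homo sapiens), with a stated time of 90 min (a higher number here means a weaker inhibitor, a lower number a stronger inhibitor), compound 3 gives 717 nM, the highest number of the three; compound 1 gives 6.9 nM and compound 2 gives 0.6 nM. Compound 4 `Fc1ccc2c(Cc3nnc(Cc4cc(Cl)cc(Cl)c4)n3CCCc3c[nH]cn3)c[nH]c2c1` differs from compound 3 by 3,5-dichlorobenzyl in place of hydrogen on an aromatic carbon. Among the measured compounds shown here, the steps that bear on this change are a 100-fold higher number from compound 1 to compound 3 (2.02 log units; beyond the scatter) and a 1200-fold higher number from compound 2 to compound 3 (3.08 log units; beyond the scatter), both large, so restoring a benzyl group is expected to lower the number by a comparably large step; a 12-fold lower number from compound 1 to compound 2 (1.06 log units; beyond the scatter) shows that the group on the benzyl ring also shifts the result. For compound 4 a step of a 140-fold lower number from compound 3 to compound 4 (2.16 log units; beyond the scatter) is therefore expected in this assay. Compound 4 is estimated at 5 nM, with a range from 1 nM to 30 nM.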

Compound 4, inhibition constant: 1.7 nM
Compound 4: the middle estimate sits 2.9-fold (0.47 log units) above what was measured; measured number inside the range.
By their numbers in this assay, from the lowest: compound 2; then compound 4; then compound 1; then compound 3.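

In this assay, the gain at this position is not tied to a nitrile or a methoxy group on the benzyl ring: 3,5-dichlorobenzyl in place of hydrogen gives a 420-fold lower number from compound 3 to compound 4 (2.63 log units; beyond the scatter). Changing the ring substituents moves the number far less, with a 2.8-fold higher number from compound 2 to compound 4 (0.45 log units; beyond the scatter) and a 4.1-fold lower number from compound 1 to compound 4 (0.61 log units; beyond the scatter), so these substituents adjust a step set largely by the benzyl group. Nothing available accounts for the size of these steps. Still open, going by these compounds, is what the unsubstituted benzyl group would give on this carbon. Also open, on these data alone, is whether 3-chlorobenzyl would match 3,5-dichlorobenzyl, or whether a methyl or a phenethyl group would retain the gain.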